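Second chloro on the purine-type core of a benzyl series

This account rests on a few compounds, and the source may have more. Where it says the series, first, only, none or still open, it means among the compounds named here.

Measured compounds:
compound 1, `ClCc1ccc(Cn2cnc3c(Cl)ncnc32)cc1`, 95500 nM
compound 2, `ClCc1ccc(Cn2cnc3nc(Cl)nc(Cl)c32)cc1`, 2450 nM

In a functional assay on KM12 cells (Homo sapiens) for cytotoxicity, read by sulforhodamine B assay, with a stated time of 48 h (a lower number here means that less compound is tolerated, a higher number that more compound is tolerated), compound 1 gives the highest of the two numbers shown; the nearest, compound 2, which also carries two chloro groups on its core, gives 2450 nM, a gap well beyond the scatter. Compound 3, `ClCc1ccc(Cn2cnc3c(Cl)nc(Cl)nc32)cc1`, has not yet been measured in this assay. It differs from compound 1 by chloro in place of hydrogen on an aromatic carbon. For the measured compounds named here, no step between measured compounds with exactly this change is available, so the expectation rests on what the two values show. Because compound 2 gives 2450 nM, a core bearing two chloro groups is expected to be tolerated less than that of compound 1, and the step of an 8.0-fold lower number from compound 1 to compound 3 (0.90 log units; beyond the scatter) is expected to be downward and beyond the scatter. Compound 3 is therefore estimated at 12000 nM, within 2500 nM to 60000 nM.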

Compound 3, concentration lethal to 50% of the cells: 5750 nM
Beside the measured number, compound 3's estimate is 2.1-fold (0.32 log units) above it; measured number inside the range.
By their numbers in this assay, from the lowest: compound 2; then compound 3; then compound 1.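

For the compounds shown here, this is the first step that isolates a single place: in this assay the change gives a 17-fold lower number from compound 1 to compound 3 (1.22 log units; beyond the scatter), with one chloro entering on an aromatic carbon between two ring nitrogen atoms and the rest of compound 1 unchanged. This position is therefore not silent, as a single heavy atom there, adding no ring, no net charge and no hydrogen-bond donors or acceptors, moves the number by a large step beyond the scatter. Nothing shown here accounts for the size of this step.

From the compounds shown here alone, it remains open whether the step is specific to chloro, or whether an amine, a methoxy group or a fluoro group on the same carbon would give a similar number. Going by these compounds, the role of the chloromethyl group, carried by all three compounds, is also open, and a plain methyl group in its place would address it.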